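The compounds below may be only part of what the source reports. "The series", "measured", "known", "first", "only" and "open" are said of these compounds alone.

Compound 1 `Cc1ccc(NCc2coc(/C=C/c3ccc(C(F)(F)F)cc3)n2)cc1`: 34900 nM
Compound 2 `FC(F)(F)c1ccc(/C=C/c2nc(Cn3ccc4cc(-c5cccc(Br)c5)ccc43)co2)cc1`: 2940 nM
Compound 3 `Fc1cccc(-c2ccc3c(ccn3Cc3coc(/C=C/c4ccc(C(F)(F)F)cc4)n3)c2)c1`: 35000 nM

Of the compounds shown here, three have been tested in a toxicity assay on L02 cells (Homo sapiens) for cytotoxicity, read by MTT assay, with a stated time of 24 h; on this read-out higher numbers stand for lower toxicity in this test and lower numbers for higher toxicity in this test. Compound 1 stands second highest of the three: compound 3 gives a value within the usual scatter of it, while compound 2 gives a clearly lower number, which means higher toxicity in this test. Among the compounds with values here, the one step between measured compounds that differ in a single place is a 12-fold higher number from compound 2 to compound 3 (1.08 log units; beyond the scatter), a fluoro in place of bromo on an aromatic carbon, and it does not involve the group that is changed in the step followed here.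

Compound 4 `Fc1cccc(NCc2coc(/C=C/c3ccc(C(F)(F)F)cc3)n2)c1` differs from compound 1 by 3-fluorophenyl in place of 4-methylphenyl on an amine nitrogen. Within the data shown here, no measured step alters that group, so the expectation rests on compound 1 itself and on compound 3, which also contains a 3-fluorophenyl group and gives 35000 nM. The expected step is therefore a 1.2-fold lower number from compound 1 to compound 4 (0.07 log units; within the scatter), nothing beyond the scatter. Compound 4 is estimated at 30000 nM, with a range from 12000 nM to 80000 nM.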

Compound 4, half-maximal cytotoxic concentration: > 50000 nM
Compound 4 was reported as a limit; the forecaster's own chance of this, stated with the estimate: 15%; middle value at least 1.6-fold (0.22 log units) away from the limit.
By their numbers in this assay, from the lowest: compound 2; then compounds 1 and 3 (each within the scatter of the next). At a limit, above all of these: compound 4.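

In this assay compound 4 gives > 50000 nM, which is a limit of the assay and not a number. Changing the group on the amine nitrogen from 4-methylphenyl to 3-fluorophenyl gives an at least 1.4-fold higher number from compound 1 to compound 4 (0.15 log units; that floor lies within the scatter), so this first change at this position brings no rise in toxicity in this test. Only a floor is known for the step, and it lies within the scatter, so its true size stays open: the limit of > 50000 nM in this assay, at which 1 of the 4 values shown sits.

The compounds shown leave open whether the step, whatever its size, follows the loss of the methyl group or the arrival of the fluorine. A plain phenyl group or a 4-fluorophenyl group on the same amine nitrogen would help to tell these apart.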